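This account rests on a few compounds, and the source may have more. Where it says the series, first, only, none or still open, it means among the compounds named here.

Measured so far:
compound 1 `CCCCc1cnc(CCCc2ccc(-c3ccccc3C(=O)O)cc2)[nH]1` — 5600 nM
compound 2 `O=C(O)c1ccccc1-c1ccc(CCc2ncc(CC3CCCC3)[nH]2)cc1` — 133 nM

Of the compounds shown here, two share a core and have been tested in an in vitro functional assay on cells for agonist activity at Bombesin receptor subtype-3 (Homo sapiens), read by luminescence and calcium flux; on this read-out lower numbers stand for an effect already at smaller amounts and higher numbers for an effect only at larger amounts of compound. In this assay compound 2 gives 133 nM, the lower of the two numbers; compound 1 gives 5600 nM, a gap well beyond the usual scatter, so compound 2 stands as the more potent of the pair.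

Compound 3 `N#Cc1ccc(Cc2cnc(CCc3ccc(-c4ccccc4C(=O)O)cc3)[nH]2)cc1` is not yet measured. It differs from compound 2 in one place: 4-cyanophenyl in place of cyclopentyl on a saturated chain carbon bound to an aromatic carbon. For the measured compounds named here, no measured pair shows this exact change, so the direction rests on judgment alone. A change of this kind is expected to move the number only modestly, if at all beyond the scatter, with a slight lean toward a higher value. The step from compound 2 to compound 3 is therefore estimated at a 1.9-fold higher number from compound 2 to compound 3 (0.27 log units; within the scatter). For compound 3 the expected value in this assay is 250 nM, within a range of 60 nM to 1200 nM.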

Compound 3, half-maximal effective concentration: 5890 nM
Beside the measured number, compound 3's estimate is 24-fold (1.37 log units) below it, outside the stated range (above it).
By their numbers in this assay, from the lowest: compound 2; then compounds 1 and 3 (each within the scatter of the next).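

In this assay, replacing cyclopentylmethyl with 4-cyanobenzyl gives a 44-fold higher number from compound 2 to compound 3 (1.65 log units; beyond the scatter), which shows that this position on the shared core is far from indifferent to the group it carries. For the compounds shown here, the earlier compounds offered no pair differing here alone, so this is the first direct reading of the position: here, the saturated carbon ring goes with a much lower number than the aromatic ring bearing a nitrile. No measurement shown accounts for the size of this step.

The change alters the ring and adds the nitrile at once, so the compounds shown cannot separate these two parts. A plain benzyl group would test the aromatic ring without the nitrile, while cyclohexylmethyl would show how a six-membered saturated ring fares at this position.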